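The source may hold more compounds than are shown below. What is called first, only, known or untested is meant among the compounds shown, and "the series" means these compounds.

Three measured compounds set the scene. Compound 1 `Cc1nc(N)nc(-c2c(Nc3ccn(C)n3)nc3ccc(-c4cncnc4)cn23)n1` gives 0.26 h in an in vivo ADME assay on the whole organism for metabolic stability, with Rattus norvegicus as the target, at a dose of 0.5 mg/kg by the intravenous route (a lower number here means that the compound disappears faster, a higher number that the compound lasts longer), compound 2 `CC(=O)Nc1cc(-c2c(Nc3cc[nH]n3)nc3cccnn23)nc(C)n1` gives 0.82 h, and compound 3 `Cc1nccc(-c2c(Nc3cc[nH]n3)nc3cccnn23)n1` gives 0.23 h, the lowest of the three, though its gap to compound 1 sits within the scatter. Among the compounds with values here, the one single-point step measured, a 3.6-fold lower number from compound 2 to compound 3 (0.55 log units; beyond the scatter), is the step that bears here: removing the acetamido shortened the half-life by a modest margin. Compound 4 `CNc1cc(-c2c(Nc3cc[nH]n3)nc3cccnn23)nc(C)n1` carries methylamino in place of hydrogen on an aromatic carbon, a change in the opposite sense of that exchange, with a smaller group entering. A modest rise in this assay is therefore expected, a 2.0-fold higher number from compound 3 to compound 4 (0.29 log units; within the scatter), somewhat short of the acetamido step. Compound 4 is estimated at 0.45 h, with a range from 0.2 h to 1 h.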

Compound 4, half-life in the Rattus norvegicus assay: 0.26 h
Estimate against measurement, compound 4: 1.7-fold (0.24 log units) above; low and high end bracket the measured number.
By their numbers in the Rattus norvegicus assay, from the lowest: compounds 3, 1 and 4 (each within the scatter of the next); then compound 2.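

In the Rattus norvegicus assay compound 4 gives 0.26 h, methylamino on this aromatic carbon gives a 1.1-fold higher number from compound 3 to compound 4 (0.05 log units; within the scatter) and so stays within the scatter, while a 3.2-fold lower number from compound 2 to compound 4 (0.50 log units; beyond the scatter) marks methyl in place of acetyl on the nitrogen as a modest step beyond it. The longer half-life of compound 2 therefore goes with the acetyl, not with any nitrogen substituent at this place. In a physicochemical assay for solubility, in simulated intestinal fluid (a higher number here means a more soluble compound, a lower number a less soluble compound), compound 3 gives 14 ug/mL and compound 4 gives 7 ug/mL, the exchange gives a 2.0-fold lower number from compound 3 to compound 4 (0.30 log units; within the scatter), and no measured finding here accounts for either result. As far as these compounds go, whether a propionyl group or a urea on that nitrogen would match the acetyl remains open, as does how a primary amine at this place would behave.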